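Nitro in Place of Bromo on a Shared Core

This account rests on a few compounds, and the source may have more. Where it says the series, first, only, none or still open, it means among the compounds named here.

Compound 1 `O=C(/C=C/c1ccc2c(c1)B(O)OC2)c1ccc(Br)cc1` was examined in an ADME assay on L929 cells (Mus musculus) for cytotoxicity, read by resazurin assay, with a stated time of 72 h; a higher number here means a weaker inhibitor, a lower number a stronger inhibitor. In this assay compound 1 reaches only the limit of the measurement, reported as > 10 ug/mL. Its measured neighbour, compound 2 `Cc1cccc(C(=O)/C=C/c2ccc3c(c2)B(O)OC3)c1`, carries 3-methylphenyl in place of 4-bromophenyl on a carbonyl carbon, and in this assay compound 2 gives 8.56 ug/mL. Within the data shown here, the single measured step, an at least 1.1-fold lower number from compound 1 to compound 2 (0.06 log units; that floor lies within the scatter), stays within the scatter; the limit of > 10 ug/mL in this assay, at which 1 of the 2 values shown sits, means the true size of that step is not known. Compound 3 `O=C(/C=C/c1ccc2c(c1)B(O)OC2)c1ccc([N+](=O)[O-])cc1` has not yet been measured. It differs from compound 1 in one place: nitro in place of bromo on an aromatic carbon. The change sits on an aromatic carbon of a six-membered aromatic ring of carbon only. Among the measured compounds shown here, no measured step touches a nitro group, and the only comparison available from compound 1 is the step of an at least 1.1-fold lower number from compound 1 to compound 2 (0.06 log units; that floor lies within the scatter), which did not move the number beyond the scatter. Compound 3 is therefore expected to sit near 12 ug/mL, within 5 ug/mL to 30 ug/mL, with a fair chance that this assay again reports only a limit. The step that the limit leaves unreadable from compound 1 to compound 3 is expected to stay within the scatter.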

Compound 3, half-maximal inhibitory concentration: > 10 ug/mL
Compound 3 ended at the assay's limit; the forecaster's own chance of this, stated with the estimate: 55%; the middle value is on the limit's open side.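

In this assay compound 3 gives > 10 ug/mL, which is a limit and not a number. Among these compounds, compound 1 also stands at a limit, so no step between compound 1 and compound 3 can be read: the limit of > 10 ug/mL in this assay, at which 2 of the 3 values shown sit. The compounds shown leave open whether nitro in place of bromo on an aromatic carbon changes the number at all.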